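The source may report more compounds than this note shows. Statements on the series, on what has been measured and on what is new or still open speak of the compounds shown alone.

Measured so far:
compound 1 `CCn1c(SCC(=O)Nc2ccc(C(C)=O)cc2)nnc1-c1ccc(OC)c(OC)c1` — 56%
compound 2 `CCn1c(SCC(=O)Nc2ccc(C(C)=O)cc2)nnc1-c1cc(OC)c(OC)c(OC)c1` — 46%

Both numbers come from a functional assay on the whole organism (strain albino) for inhibition, with Rattus norvegicus as the target, read by paw edema, with stated times of 30 min and 1 h, at a dose of 0.28 mmol/kg by the oral route; on this read-out higher numbers stand for more inhibition at the one dose given (going by the name of the read-out) and lower numbers for less inhibition. Within the data shown here, the single measured step, a number 10 percentage points lower from compound 1 to compound 2 (within the scatter), concerns a methoxy in place of hydrogen on an aromatic carbon, and it lies within the usual scatter; so the two measured numbers cannot be told apart, and compound 2 stands level with compound 1 rather than apart from it.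

Compound 3 `COc1cc(-c2nnc(SCC(=O)Nc3ccc(C(C)=O)cc3)n2-c2ccccc2)cc(OC)c1OC` is not yet measured. It differs from compound 2 in one place: phenyl in place of ethyl on an aromatic nitrogen. Among the measured compounds shown here, no measured step touches the group on the ring nitrogen, so the one step seen gives no guide to this change, only a sense that a small edit to this core can leave the number inside the scatter. Compound 3 is therefore expected to sit close to compound 2, with the step of a number 1 percentage points lower from compound 2 to compound 3 (within the scatter) expected to be no larger than the scatter, and its estimated value is 45%, between 25% and 65%.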

Compound 3, a percentage reported as inhibition, in the whole organism at one dose (the size of the read-out at that dose, not a potency): 49%
The estimate for compound 3 lay 4 percentage points below the measured number; the range from low to high includes it.
By their numbers in this assay, from the lowest: compounds 2, 3 and 1 (each within the scatter of the next).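

Phenyl in place of ethyl is the first change seen on the aromatic nitrogen, and in this assay it gives a number 3 percentage points higher from compound 2 to compound 3 (within the scatter). At this nitrogen, next to two ring atoms that each bear a large group, a substituent of 6 heavy atoms with a six-membered aromatic ring therefore replaces one of 2 heavy atoms with no difference that can be told from the scatter. Nothing available explains why the reading holds across this change.

The compounds shown leave open how a benzyl group, a longer chain such as butyl, or a chain ending in an amine would read on this nitrogen. They also leave open whether phenyl in place of ethyl would give the same outcome on the core of compound 1, which carries one methoxy fewer.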